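Adding One Methyl Where Every Value So Far Is a Limit

The source may report more compounds than this note shows. Statements on the series, on what has been measured and on what is new or still open speak of the compounds shown alone.

Compound 1 `O=C(O)c1ccc(/C=C2\SC(=S)N(c3ccccc3)C2=O)cc1`: > 10000 nM
Compound 2 `Cc1ccccc1N1C(=O)/C(=C/c2ccc(OCC(=O)Nc3ccc(C(=O)O)cc3)cc2)SC1=S`: > 10000 nM
Compound 3 `Cc1cccc(N2C(=O)/C(=C/c3ccc(OCc4ccc(C(=O)O)cc4)cc3)SC2=S)c1`: > 10000 nM

Among the compounds with values here, the three compounds measured so far were read in an assay on isolated protein for inhibition of Apoptosis regulator Bcl-2 (Homo sapiens), read by fluorescence polarization; on this read-out lower numbers stand for stronger inhibition and higher numbers for weaker inhibition. For compound 1 the figure is a limit of the assay, not a number. For compound 2 the figure is likewise a limit. For compound 3 the figure is again a limit. Compound 2 therefore stands at the limit of > 10000 nM in this assay, at which 3 of the 3 values shown sit, and none of the three can be placed above or below another.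

Compound 4 `Cc1cccc(C)c1N1C(=O)/C(=C/c2ccc(OCC(=O)Nc3ccc(C(=O)O)cc3)cc2)SC1=S` is the unmeasured partner of compound 2. The difference between them is that (methyl in place of hydrogen on an aromatic carbon); cut one bond further out, the change reads 2-methylphenyl to 2,6-dimethylphenyl. Within the data shown here, no pair of measured compounds differs in one place, so no measured step of this kind is known.

With compound 2 itself at the limit and only a single methyl carbon added, compound 4 is expected to return a value at the limit as well, and the step that the limit leaves unreadable from compound 2 to compound 4 is expected to be none beyond the scatter. The estimate for compound 4 is 15000 nM, with a range from 5000 nM to 50000 nM.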

Compound 4, inhibition constant: 7600 nM
Compound 4: the middle estimate sits 2.0-fold (0.30 log units) above what was measured; the range from low to high includes it.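

In this assay compound 4, which carries a 2,6-dimethylphenyl group, gives 7600 nM, the first number among the compounds shown and the first reading in this series that is not a limit. From the compounds shown here alone, compound 2 remains a limit of the assay, so its true position is unknown: the limit of > 10000 nM in this assay, at which 3 of the 4 values shown sit. The added methyl, ortho to a large group, therefore gives only a floor, an at least 1.3-fold lower number from compound 2 to compound 4 (0.11 log units; that floor lies within the scatter), and that floor does not by itself separate the two compounds, although the true step could be larger.

Going by these compounds, it remains open whether an ethyl group or a chlorine atom at the same place on the aromatic ring would also give a number, and whether a methoxy group there would read differently from methyl. On these data alone, it is equally open whether the 2,6-dimethylphenyl group would return a number on the rest of compound 3, and whether a tetrazole in place of the carboxylic acid of compound 4 would keep the reading within range.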